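A few compounds are considered here, and "the series" means these few. Any claim that something is new, unique, unknown or untested is made for them only; others in the source may bear on it.

Measured so far:
compound 1, `Cc1ccccc1CNc1nn(-c2ccc(F)cc2F)cc1CNCCN1CCN(C)CC1`: > 20000 nM
compound 2, `COc1ccc(-n2cc(CNCCN3CCN(C)CC3)c(-c3ccccc3C)n2)cc1`: > 20000 nM

The read-out here is an ADME assay on Huh-7 cells (Homo sapiens) for cytotoxicity; on this read-out higher numbers stand for lower toxicity in this test and lower numbers for higher toxicity in this test. For compound 1 the result is a limit of the test rather than a number: in this assay compound 1 gives > 20000 nM. Compound 2 likewise reaches only a limit, giving > 20000 nM in this assay. Compound 1 therefore stands where every other measured value also stands, (the limit of > 20000 nM in this assay, at which 2 of the 2 values shown sit). Among the compounds with values here, no two measured compounds differ in a single place, so no step size between measured compounds is known.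

Compound 3, `CN1CCN(CCNCc2cn(-c3ccc(F)cc3F)nc2-c2ccc(N(C)C)cc2)CC1`, has not yet been measured. It is compound 1 with the same atoms joined differently: 4-(dimethylamino)phenyl in place of (2-methylbenzyl)amino on an aromatic carbon. With both known values sitting at the limit, the step that the limit leaves unreadable from compound 1 to compound 3 is expected to be none beyond the scatter, although a reading at a lower concentration cannot be excluded from the two values alone. Compound 3 is estimated at 25000 nM in this assay, with a range from 8000 nM to 80000 nM.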

Compound 3, half-maximal cytotoxic concentration: > 20000 nM
Compound 3 was reported as a limit; the forecaster's own chance of this, stated with the estimate: 70%; the middle value is on the limit's open side.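

In this assay compound 3 gives > 20000 nM, which is a limit of the test and not a number. Compound 1 also sits at a limit, so no step between compound 1 and compound 3 can be read, because the values all share one limit: the limit of > 20000 nM in this assay, at which 3 of the 3 values shown sit.

The compounds shown leave open how far each lies beyond that limit, and whether any change to the shared core gives a numerical reading in this test.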